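This account rests on a few compounds, and the source may have more. Where it says the series, first, only, none or still open, it means among the compounds named here.

Measured compounds in a functional assay on DU-145 cells (Homo sapiens) for cytotoxicity, read by MTT assay, with a stated time of 48 h; a higher number here means a weaker inhibitor, a lower number a stronger inhibitor: compound 1 `Cc1ccc(S(=O)(=O)/N=C(/CCNC2=CC(=O)c3ccccc3C2=O)Nc2ccccc2I)cc1` gives 11700 nM; compound 2 `Cc1ccc(S(=O)(=O)/N=C(/CCNC2=CC(=O)c3ccccc3C2=O)Nc2cccc(C(F)(F)F)c2)cc1` gives 84100 nM; compound 3 `COc1ccc(N/C(CCNC2=CC(=O)c3ccccc3C2=O)=N\S(=O)(=O)c2ccc(C)cc2)cc1OC` gives 17800 nM.

Compound 3 stands second highest of the three numbers in this assay. Its nearest neighbour is compound 1, the step of a 1.5-fold higher number from compound 1 to compound 3 (0.18 log units; within the scatter) lying within the scatter; its furthest is compound 2, with a 4.7-fold lower number from compound 2 to compound 3 (0.67 log units; beyond the scatter).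

Compound 4 `COc1ccc(N/C(CCNC2=CC(=O)c3ccccc3C2=O)=N\S(=O)(=O)c2ccc(C)cc2)c(OC)c1` differs from compound 3 by 2,4-dimethoxyphenyl in place of 3,4-dimethoxyphenyl on an amine nitrogen. Among the compounds with values here, no measured step exchanges one dimethoxyphenyl for another; the steps on this nitrogen, a 7.2-fold higher number from compound 1 to compound 2 (0.86 log units; beyond the scatter), a 1.5-fold higher number from compound 1 to compound 3 (0.18 log units; within the scatter) and a 4.7-fold lower number from compound 2 to compound 3 (0.67 log units; beyond the scatter), all swap unrelated aryl groups, and the rearranged group keeps the same atoms. A step of a 1.1-fold lower number from compound 3 to compound 4 (0.05 log units; within the scatter) is therefore expected, not beyond the scatter. Compound 4 is estimated at 16000 nM, range 5000 nM to 50000 nM.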

Compound 4, half-maximal inhibitory concentration: 67300 nM
The estimate for compound 4 lay 4.2-fold (0.62 log units) below the measured number; the measured number lies above the stated range.
By their numbers in this assay, from the lowest: compounds 1 and 3 (each within the scatter of the next); then compounds 4 and 2 (each within the scatter of the next).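

Placing 2,4-dimethoxyphenyl in place of 3,4-dimethoxyphenyl on the amine nitrogen keeps the same atoms yet gives a 3.8-fold higher number from compound 3 to compound 4 (0.58 log units; beyond the scatter) in this assay, so the arrangement of the two methoxy groups matters at this position, and not only which atoms the group holds. The 2,4-dimethoxyphenyl group cannot be told apart from 3-(trifluoromethyl)phenyl, a 1.2-fold lower number from compound 2 to compound 4 (0.10 log units; within the scatter), but it does separate from 2-iodophenyl, a 5.8-fold higher number from compound 1 to compound 4 (0.76 log units; beyond the scatter). No measurement shown accounts for this difference between the two dimethoxyphenyl groups.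

The compounds shown leave open whether a single methoxy group carries the change, as 2-methoxyphenyl or 4-methoxyphenyl on this nitrogen would test. They also leave open where an unsubstituted phenyl group would fall.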